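This account rests on a few compounds, and the source may have more. Where it says the series, first, only, none or still open, it means among the compounds named here.

Measured compounds:
- Compound 1, `CC(C)c1cccc(C(C)C)c1NC(=O)NS(=O)(=O)N1CCCC1`: 15000 nM
- Compound 2, `CC(C)c1cccc(C(C)C)c1NC(=O)NS(=O)(=O)N1CCCCC1`: 17000 nM
- Compound 3, `CC(C)c1cccc(C(C)C)c1NC(=O)NS(=O)(=O)N(C(C)C)C(C)(C)C`: 140 nM

All three share one core and differ only in the amine attached to the sulfonyl sulfur. In an assay on liver for inhibition of sterol O-acyltransferase 1 (Rattus norvegicus), using microsomes (on this read-out higher numbers stand for weaker inhibition and lower numbers for stronger inhibition), compound 3 gives 140 nM, the lowest number of the three. Compound 1 and compound 2 carry the two cyclic amines, and the step of a 1.1-fold higher number from compound 1 to compound 2 (0.05 log units; within the scatter) shows that the two rings give numbers indistinguishable from each other. The acyclic, branched amine of compound 3 stands apart: a 110-fold lower number from compound 1 to compound 3 (2.03 log units; beyond the scatter) and a 120-fold lower number from compound 2 to compound 3 (2.08 log units; beyond the scatter).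

Compound 4, `CC(C)CN(CC(C)C)S(=O)(=O)NC(=O)Nc1c(C(C)C)cccc1C(C)C`, keeps that acyclic pattern but changes the branching: diisobutylamino in place of isopropyl(tert-butyl)amino on a sulfonyl sulfur. Both measured steps that bear on this position say the same thing, that leaving the rings for an acyclic amine brings a large drop in the number; they say nothing about one acyclic amine against another. With that limited basis, compound 4 is expected to stay well below the cyclic compounds but may not fully match compound 3, so a moderate rise is estimated: a 4.3-fold higher number from compound 3 to compound 4 (0.63 log units; beyond the scatter). The expected value for compound 4 in this assay is 600 nM, with a range from 100 nM to 4000 nM.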

Compound 4, half-maximal inhibitory concentration: 420 nM
Beside the measured number, compound 4's estimate is 1.4-fold (0.15 log units) above it; the range from low to high includes it.
By their numbers in this assay, from the lowest: compound 3; then compound 4; then compounds 1 and 2 (each within the scatter of the next).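

A second acyclic amine now stands well apart from the two rings in this assay: the steps of a 40-fold lower number from compound 2 to compound 4 (1.61 log units; beyond the scatter) and a 36-fold lower number from compound 1 to compound 4 (1.55 log units; beyond the scatter) show that the large drop on leaving the rings does not belong to the isopropyl(tert-butyl)amino group alone. Among these compounds, the new result also gives the first comparison of one acyclic amine with another, and the choice matters here: diisobutylamino in place of isopropyl(tert-butyl)amino gives a 3.0-fold higher number from compound 3 to compound 4 (0.48 log units; beyond the scatter) and so lies beyond the scatter, though this step is modest beside the large steps from the rings. No measurement at hand accounts for either the large steps or the modest one.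

Both acyclic amines shown carry branched chains, so it remains open whether an unbranched amine such as di-n-butylamino would keep the low number or whether a small one such as dimethylamino would fall closer to the rings. Going by these compounds, a ring holding a second heteroatom, such as morpholine, also remains open, as does whether any other ring at this sulfonyl sulfur would differ from the pyrrolidin-1-yl and piperidin-1-yl groups.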